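A few compounds are considered here, and "the series" means these few. Any claim that something is new, unique, unknown or untested is made for them only; others in the source may bear on it.

Measured so far:
- Compound 1 `N#Cc1ccc(NC(=O)c2cc(-c3cccnc3)ccc2O)cc1`: 7960 nM
- Compound 2 `N#Cc1ccc(NC(=O)c2ccc[nH]c2=O)cc1`: > 10000 nM (a limit)

Within the data shown here, in a functional assay on HL-60 cells (Homo sapiens) for cytotoxicity, read by luminescence and CellTiter-Glo, with a stated time of 3 days (on this read-out lower numbers stand for stronger inhibition and higher numbers for weaker inhibition), compound 1 gives 7960 nM, the only actual number so far. Compound 2 is reported only as a limit, > 10000 nM.

The next compound is compound 3 `N#Cc1ccc(NC(=O)c2cc(Br)ccc2O)cc1`, which keeps the core of compound 1 but carries bromo in place of pyridin-3-yl on an aromatic carbon, para to a hydroxy group (bromo in place of pyridin-3-yl on an aromatic carbon). Among the measured compounds shown here, no measured pair shows this change, so in this assay the expected 1.3-fold lower number from compound 1 to compound 3 (0.12 log units; within the scatter) stays within the usual scatter, with no clear direction. For compound 3 the estimated value is 6000 nM, with an expected range of 2000 nM to 14000 nM.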

Compound 3, half-maximal inhibitory concentration: 620 nM
Compound 3: the middle estimate sits 9.7-fold (0.99 log units) above what was measured; the whole stated range lies above it.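

Putting bromo in place of pyridin-3-yl, para to a hydroxy group, gives a 13-fold lower number from compound 1 to compound 3 (1.11 log units; beyond the scatter) in this assay, so what this position carries clearly matters to the read-out. The pair also shows that an aromatic ring is not needed there for the lower number. Nothing measured here explains the size of this step.

Going by these compounds, whether the gain belongs to bromo itself or to the loss of the pyridin-3-yl ring stays open, as one pair cannot separate the two. How chloro, methyl or an unsubstituted phenyl ring would read at this position is also unknown.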